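Swapping the Acyl Group on Compound 3

The source may report more compounds than this note shows. Statements on the series, on what has been measured and on what is new or still open speak of the compounds shown alone.

Compound 1 `C=CC(=O)NCc1ccc(C(=O)Nc2ccc(C)c(Nc3nccc(-c4cccnc4)n3)c2)cc1`: > 10000 nM (a limit)
Compound 2 `C=CS(=O)(=O)NCc1ccc(C(=O)Nc2ccc(C)c(Nc3nccc(-c4cccnc4)n3)c2)cc1`: 7710 nM
Compound 3 `C/C=C/C(=O)N(CCN(C)C)Cc1ccc(C(=O)Nc2ccc(C)c(Nc3nccc(-c4cccnc4)n3)c2)cc1`: > 10000 nM (a limit)

All three compounds were tested in an ADME assay on BaF3 cells (Mus musculus) for cytotoxicity, read by CellTiter-Glo and CCK-8 assay, with a stated time of 72 h; a lower number here means a stronger inhibitor of growth, a higher number a weaker inhibitor of growth. Compound 3 gives no number there, and its > 10000 nM is a limit of the assay. Compound 1 also stands at a limit, > 10000 nM. Together they make up (the limit of > 10000 nM in this assay, at which 2 of the 3 values shown sit). Going by the values given here, compound 2 is the only one with a number, 7710 nM.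

Compound 4 `Cc1ccc(NC(=O)c2ccc(CN(CCN(C)C)C(=O)C(C)(C)C)cc2)cc1Nc1nccc(-c2cccnc2)n1` changes a single group of compound 3: tert-butyl in place of prop-1-en-1-yl on a carbonyl carbon. The measured steps nearby give little to go on. The readings show an at least 1.2-fold lower number from compound 1 to compound 2 (0.11 log units; that floor lies within the scatter), and they show an at least 1.2-fold higher number from compound 2 to compound 3 (0.11 log units; that floor lies within the scatter). Between the two limits there is a step that the two limits leave unreadable from compound 1 to compound 3. None of these steps exchanges prop-1-en-1-yl for tert-butyl alone, so none sets a size for this change.

No step beyond the scatter is therefore expected in this assay, and another limit is the likeliest report. The expectation rests on compound 3, which reads > 10000 nM. The expected step is a number no higher from compound 3 to compound 4 (the limit leaves the size open). For compound 4 the estimate is 10000 nM, with an expected range from 5000 nM to 20000 nM.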

Compound 4, concentration for 50% growth inhibition: > 10000 nM
Compound 4 was reported as a limit; the forecaster's own chance of this, stated with the estimate: 75%; the middle value sits exactly at the limit.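

Compound 4 shows that at this carbonyl carbon, whose other neighbour is an amide-type nitrogen, tert-butyl, which carries no double bond outside aromatic rings, ends at the same limit of this assay as prop-1-en-1-yl does in compound 3: the limit of > 10000 nM in this assay, at which 3 of the 4 values shown sit. The steps linking compound 4 to compound 3 and to compound 1 cannot be read, with a limit at both ends of each. Going by these compounds alone, the one step that can be read is an at least 1.2-fold higher number from compound 2 to compound 4 (0.11 log units; that floor lies within the scatter), so this reading does not set compound 4 apart from compound 2.

From the compounds shown here alone, what stays open is how far past the limit compound 3 and compound 4 lie, and whether the two differ from each other at all. Going by these compounds, it is also open whether another group on this carbonyl carbon, such as a phenyl ring, a longer chain or one ending in a carboxylic acid, would bring a number inside the range of this assay.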